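Methoxy in place of hydrogen on the shared core

The source may hold more compounds than are shown below. What is called first, only, known or untested is meant among the compounds shown, and "the series" means these compounds.

In an assay on BTI cells for inhibition of Amine oxidase [flavin-containing] B (Homo sapiens), read by fluorescence, with a stated time of 20 min, tested at 1 uM (on this read-out higher numbers stand for more inhibition at the one concentration tested (going by the name of the read-out) and lower numbers for less inhibition), compound 3 `CC1(C)COc2ccccc2C1=O` gives 9.2%. Compound 2 `COc1cccc2c1C(=O)C(C)(C)CO2` differs from compound 3 by methoxy in place of hydrogen on an aromatic carbon, and in this assay compound 2 gives 5.9%; the step of a number 3.3 percentage points lower from compound 3 to compound 2 (within the scatter) lies within the scatter. Compound 1 `CC1(C)COc2ccccc2C1O` gives 8% in this assay, a value within the scatter of that of compound 3 and also of that of compound 2, so no order among the three can be read from these numbers. How the core of compound 1 differs from the core of compound 3 is not broken down here.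

Compound 4 `COc1cccc2c1C(O)C(C)(C)CO2` has not yet been measured in this assay. It differs from compound 1 by methoxy in place of hydrogen on an aromatic carbon, the same change that turns compound 3 into compound 2, at a place described in the same words. Within the data shown here, from compound 1 to compound 4 the expected step is a number 3 percentage points lower from compound 1 to compound 4 (within the scatter), and this expectation rests on the one measured example of the change, a number 3.3 percentage points lower from compound 3 to compound 2 (within the scatter), which stayed within the scatter. Compound 4 is therefore expected to give about 5% in this assay, with a range from -2% to 13%.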

Compound 4, a percentage reported as inhibition, at one concentration (the size of the read-out at that concentration, not a potency): 5.3%
Beside the measured number, compound 4's estimate is 0.3 percentage points below it; the measured number falls inside the stated range.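

In this assay, among these compounds, methoxy in place of hydrogen on an aromatic carbon now has a second example, a number 2.7 percentage points lower from compound 1 to compound 4 (within the scatter), and the two examples compare as follows: the same change on two cores in this assay, a number 3.3 percentage points lower (within the scatter) from compound 3 to compound 2 and a number 2.7 percentage points lower (within the scatter) from compound 1 to compound 4, 0.6 percentage points apart, within the scatter of two such steps On these two cores, the ketone of compound 3 and the alcohol of compound 1, the change therefore gives the same reading: no step that can be told from the scatter. Among the compounds shown here, this shows only that the change left the read-out within the scatter on both cores; with neither step beyond the scatter, the agreement does not show that a measurable effect of methoxy carries from one core to another, and two cores do not establish a rule for the series.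

Open, as far as these compounds go, is whether a different group on that aromatic carbon, such as an amine, a carboxylic acid or a longer chain, would give a step beyond the scatter, and how methoxy would behave at another place on the ring. The read-out at one concentration also leaves the potency of all four compounds open.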